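A few compounds are considered here, and "the series" means these few. Any claim that something is new, unique, unknown or untested is made for them only; others in the source may bear on it.

In a physicochemical assay for solubility (a lower number here means a less soluble compound, a higher number a more soluble compound), three compounds sharing one core have been measured so far. Compound 1 `CNC(=O)c1cc(C(=O)NC2CC2)cn(Cc2ccc(F)cc2)c1=O` gives >= 162 ug/mL, which is a limit. Compound 2 `CNC(=O)c1cc(C(=O)NC2CC2)cn(Cc2cccc(F)c2)c1=O` gives >= 133 ug/mL, again a limit. Compound 3 `CNC(=O)c1cc(C(=O)NC2CC2)cn(CC2CCCCC2)c1=O` gives >= 148 ug/mL, also a limit, so it has no exact number of its own. Compound 4 `CNC(=O)c1cc(C(=O)NC2CC2)cn(Cc2cccc([C@@H](C)O)c2)c1=O` carries 3-(1-hydroxyethyl)phenyl in place of cyclohexyl on a saturated chain carbon bound to an aromatic nitrogen. Among the measured compounds shown here, the steps that bear on this change are a step that the two limits leave unreadable from compound 2 to compound 3 and a step that the two limits leave unreadable from compound 1 to compound 3, with a step that the two limits leave unreadable from compound 1 to compound 2 alongside them, and none has a readable size. No change beyond the scatter is therefore expected in this assay, and the estimated step is a step that the limit leaves unreadable from compound 3 to compound 4. Compound 4 is expected at 150 ug/mL, within a range of 90 ug/mL to 200 ug/mL.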

Compound 4, solubility: >= 131 ug/mL
Compound 4: only a limit was reported; the forecaster's own chance of this, stated with the estimate: 75%; the middle value does not contradict the limit.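

In this assay, among the compounds shown here, the result for compound 4 is a limit, as are those for compound 1, compound 2 and compound 3, and no step among them can be read. The compounds shown leave open whether these four differ in solubility at all.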